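The compounds below may be only part of what the source reports. "The series", "measured", "known", "first", "only" and "open" are said of these compounds alone.

Measured in a functional assay on NCI-H460 cells (Homo sapiens) for cytotoxicity, read by MTT assay, with a stated time of 72 h; on this read-out lower numbers stand for stronger inhibition and higher numbers for weaker inhibition:
- compound 1 `CC1CCN(Cc2ccc3nc(NC(=O)N/N=C/c4cn(Cc5ccc(Cl)cc5Cl)c5ccccc45)sc3c2)CC1`: 1660 nM
- compound 2 `CCN(CC)Cc1ccc2nc(NC(=O)N/N=C/c3cn(Cc4ccc(Cl)cc4Cl)c4ccccc34)sc2c1`: 1080 nM
- compound 3 `CN(C)Cc1ccc2nc(NC(=O)N/N=C/c3cn(Cc4ccc(Cl)cc4)c4ccccc34)sc2c1`: 290 nM

Compound 1, at 1660 nM, sits at the upper end of these numbers. Its nearest neighbour is a 1.5-fold lower number from compound 1 to compound 2 (0.19 log units; within the scatter), while compound 3 lies clearly lower at 290 nM.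

Compound 4 `CC1CCN(Cc2ccc3nc(NC(=O)N/N=C/c4cn(Cc5ccccc5Cl)c5ccccc45)sc3c2)CC1` differs from compound 1 in one place: hydrogen in place of chloro on an aromatic carbon. This is hydrogen in place of chloro on an aromatic carbon, turning 2,4-dichlorobenzyl into 2-chlorobenzyl.

Among the measured compounds shown here, no measured step covers this change. For the measured compounds named here, the only single-place step, a 1.5-fold lower number from compound 1 to compound 2 (0.19 log units; within the scatter), is diethylamino in place of 4-methylpiperidin-1-yl, so it bears on the change only indirectly and gives no size to carry over. With nothing pointing either way, no shift beyond the scatter is expected in this assay, though the uncertainty is wide. The estimated step is a 1.2-fold lower number from compound 1 to compound 4 (0.07 log units; within the scatter). For compound 4 the expected value is 1400 nM. The expected range for compound 4 runs from 550 nM to 3500 nM.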

Compound 4, half-maximal inhibitory concentration: 1080 nM
Compound 4: the middle estimate sits 1.3-fold (0.11 log units) above what was measured, and the stated range covers the measured number.
By their numbers in this assay, from the lowest: compound 3; then compounds 2, 4 and 1 (each within the scatter of the next).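

In this assay the loss of the chloro group para to a large group, which turns 2,4-dichlorobenzyl into 2-chlorobenzyl, gives a 1.5-fold lower number from compound 1 to compound 4 (0.19 log units; within the scatter) and so stays within the scatter. The earlier compounds shown here held no single-place step on the benzyl group; this one shows that, with the 4-methylpiperidin-1-yl group kept, hydrogen can stand in place of this chloro without a change that can be told from the scatter. Nothing in the data shown gives a reason for this result.

Going by these compounds, whether a methoxy or a trifluoromethyl group in the place of this chloro would move the number beyond the scatter remains open. Also open, on these data alone, is whether the same exchange would read alike with diethylamino in place of 4-methylpiperidin-1-yl.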